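A few compounds are considered here, and "the series" means these few. Any claim that something is new, unique, unknown or untested is made for them only; others in the source may bear on it.

Compound 3 `COc1ccc(-c2nn(-c3ccccc3)cc2C(=O)Nc2nc3ccc(Cl)cc3s2)cc1` gives 12600 nM in an ADME assay on HEK-293T cells (Homo sapiens) for cytotoxicity, read by MTT assay, with a stated time of 72 h; on this read-out higher numbers stand for weaker inhibition and lower numbers for stronger inhibition. That is the lowest of the two numbers shown, but compound 2 `COc1ccc(-c2nn(-c3ccccc3)cc2C(=O)Nc2nc3ccccc3s2)cc1`, at 18900 nM, lies within the scatter of it, so the two cannot be told apart. Compound 1 `Cc1ccc2nc(NC(=O)c3cn(-c4ccccc4)nc3-c3ccccc3)sc2c1` reaches only a limit in this assay, > 50000 nM. Compound 4 `COc1ccc(-c2nn(-c3ccccc3)cc2C(=O)Nc2nc3ccc(C)cc3s2)cc1` differs from compound 3 by methyl in place of chloro on an aromatic carbon. For the measured compounds named here, the one measured step at the same place, a 1.5-fold lower number from compound 2 to compound 3 (0.18 log units; within the scatter), stayed within the scatter. A swap of chloro for methyl is therefore expected to move the number little if at all, though with the limit of > 50000 nM in this assay, at which 1 of the 3 values shown sits, in view a limit cannot be ruled out. Compound 4 is estimated at 16000 nM, between 6000 nM and 50000 nM, meaning an expected step of a 1.3-fold higher number from compound 3 to compound 4 (0.10 log units; within the scatter).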

Compound 4, half-maximal inhibitory concentration: > 50000 nM
Compound 4: a limit, no number; the forecaster's own chance of this, stated with the estimate: 25%; middle value at least 3.1-fold (0.49 log units) away from the limit.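

Hydrogen and chloro at this place on the ring could not be told apart, but methyl stands clear of both in this assay: the result is an at least 3.9-fold higher number from compound 3 to compound 4 (0.59 log units; beyond the scatter) and an at least 2.6-fold higher number from compound 2 to compound 4 (0.42 log units; beyond the scatter). So the read-out does respond to the group here, and a swap of one heavy atom is enough to move it beyond the scatter. The step between compound 1 and compound 4 joins two limits and cannot be read.

On these data alone, whether an amine or a carboxylic acid here would behave like chloro or like methyl stays open. How large the methyl steps really are also stays open, because the reading for compound 4 ends at a limit: the limit of > 50000 nM in this assay, at which 2 of the 4 values shown sit.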